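Working notes: from compound 1 to compound 4

A few compounds are considered here, and "the series" means these few. Any claim that something is new, unique, unknown or untested is made for them only; others in the source may bear on it.

Measured in a functional assay on IMR-32 cells (Homo sapiens) for antiproliferative activity, read by MTT assay; a higher number here means a weaker inhibitor, a lower number a stronger inhibitor:
- compound 1 (`CC1(C)CCc2cc(C(=O)/C=C/c3ccc(OCc4cn(-c5ccc(Br)cc5)nn4)cc3)c(O)cc2O1`): 69400 nM
- compound 2 (`Cc1c(-n2cc(COc3ccc(/C=C/C(=O)c4ccc5c(c4O)CCC(C)(C)O5)cc3)nn2)cccc1[N+](=O)[O-]`): 73500 nM
- compound 3 (`Cc1ccc(-n2cc(COc3ccc(/C=C/C(=O)c4ccc5c(c4O)CCC(C)(C)O5)cc3)nn2)cc1Br`): "not active" (no number reported)

Among the compounds with values here, only two numbers exist so far. Compound 1 stands level with compound 2 within the scatter, and compound 3 has no number to place beside them. Within the data shown here, no step between measured compounds that differ in one place is available, so the series offers no direct guide to a single change.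

The next entry is compound 4 (`CC1(C)CCc2cc(C(=O)/C=C/c3ccc(OCc4cn(Cc5ccc([N+](=O)[O-])cc5)nn4)cc3)c(O)cc2O1`), which carries 4-nitrobenzyl in place of 4-bromophenyl on an aromatic nitrogen.

In this assay no step beyond the scatter is expected, and no direction is favoured. This expectation rests on compound 1 (69400 nM) and compound 2 (73500 nM), whose numbers lie within the scatter of each other. An outcome without a number, as for compound 3, remains possible.

The expected change is a 1.3-fold lower number from compound 1 to compound 4 (0.10 log units; within the scatter).

For compound 4 the estimate is 55000 nM, with an expected range from 20000 nM to 120000 nM.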

Compound 4, half-maximal inhibitory concentration: 108000 nM
Compound 4: the middle estimate sits 2.0-fold (0.29 log units) below what was measured; low and high end bracket the measured number.
By their numbers in this assay, from the lowest: compounds 1, 2 and 4 (each within the scatter of the next).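

Within the data shown here, on the aromatic nitrogen of the five-membered aromatic ring, putting 4-nitrobenzyl in place of 4-bromophenyl gives in this assay a 1.6-fold higher number from compound 1 to compound 4 (0.19 log units; within the scatter) and is the first direct reading of a single change. The position therefore tolerates this exchange without a step beyond the scatter, although the entering group has more heavy atoms and brings hydrogen-bond acceptors that the leaving group lacks. No measurement at hand explains the outcome. The exchange alters the group on the ring and its link to the nitrogen together, so 4-bromobenzyl or 4-nitrophenyl would be needed to read each part alone. Also open, from the compounds shown here alone, is whether an amine or a carboxylic acid on that six-membered aromatic ring would give a step beyond the scatter.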